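A few compounds are considered here, and "the series" means these few. Any claim that something is new, unique, unknown or untested is made for them only; others in the source may bear on it.

Compound 1 `Oc1ccccc1-c1cc(-c2ccsc2)cc(-c2ccccc2O)n1` was tested in a functional assay on HeLa cells (Homo sapiens) for cytotoxicity, read by CCK-8 assay; a lower number here means a stronger inhibitor, a higher number a weaker inhibitor. In this assay compound 1 gives only a limit, > 50000 nM. Compound 2 `Oc1cccc(-c2cc(-c3ccsc3)cc(-c3ccccc3O)n2)c1` differs from it in one place (3-hydroxyphenyl in place of 2-hydroxyphenyl on an aromatic carbon). In this assay compound 2 also gives only a limit, > 50000 nM. The step that the two limits leave unreadable from compound 1 to compound 2 therefore cannot be sized, because of the limit of > 50000 nM in this assay, at which 3 of the 3 values shown sit. Compound 3 `Oc1cccc(-c2cc(-c3ccco3)cc(-c3ccccc3O)n2)c1` follows from compound 2 with furan-2-yl in place of thiophen-3-yl on an aromatic carbon, and the step that the two limits leave unreadable from compound 2 to compound 3 is equally unreadable. In this assay compound 3 gives only a limit, > 50000 nM. The difference between the cores of compound 1 and compound 3 is not broken down here. Compound 4 `Oc1cccc(-c2cc(-c3ccco3)cc(-c3cccc(O)c3)n2)c1` is not yet measured; it differs from compound 3 by 3-hydroxyphenyl in place of 2-hydroxyphenyl on an aromatic carbon. This is the same kind of change as from compound 1 to compound 2, though there the place was meta to a 2-hydroxyphenyl group and meta to a thiophen-3-yl group, while here it is meta to a 3-hydroxyphenyl group and meta to a furan-2-yl group. Among the measured compounds shown here, since every value so far sits at the limit described by the limit of > 50000 nM in this assay, at which 3 of the 3 values shown sit, the step that the limit leaves unreadable from compound 3 to compound 4 is expected to be unreadable as well. Compound 4 is estimated at 100000 nM, most likely reported again only as a limit.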

Compound 4, half-maximal inhibitory concentration: 5990 nM
For compound 4 the middle estimate is 17-fold (1.22 log units) above the measured one; measured number outside the range, below it.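

In this assay, putting 3-hydroxyphenyl in place of 2-hydroxyphenyl gives an at least 8.3-fold lower number from compound 3 to compound 4 (0.92 log units; beyond the scatter), on a core that already carries a 3-hydroxyphenyl group and a furan-2-yl group. From the compounds shown here alone, the step is only a minimum, and the true size remains unknown. The same change on the core of compound 1 cannot be read, nor can the other earlier step, so this single readable case does not show that the gain carries from one core to another, because both ends of those steps are limits: the limit of > 50000 nM in this assay, at which 3 of the 4 values shown sit.

Going by these compounds, it remains open whether a thiophen-3-yl core with two 3-hydroxyphenyl groups would behave like compound 4. Also open, on these data alone, is what an amine or a carboxylic acid would do in place of the hydroxyl groups.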